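This account rests on a few compounds, and the source may have more. Where it says the series, first, only, none or still open, it means among the compounds named here.

Compound 2, `Cc1cc(C(=O)O)ccc1OC[C@H](C)COc1ccc(C(=O)CC(C)(C)C)c(O)c1C`, was tested in an assay for positive allosteric modulation of metabotropic glutamate receptor 3 (Rattus norvegicus) (a higher number here means that more compound is needed for the effect, a lower number that less compound is needed), where compound 2 gives 1520 nM. Among the compounds with values here, only one other compound stands beside it: compound 1, `Cc1c(OCCCCOc2ccc(C(=O)O)cc2F)ccc(C(=O)CC(C)(C)C)c1O`, which in this assay gives 1230 nM. These two numbers lie within the usual scatter of one another, so on the numbers shown compound 2 stands level with compound 1 rather than apart from it.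

Compound 3, `Cc1c(OC[C@@H](C)COc2ccc(C(=O)O)c(Cl)c2)ccc(C(=O)CC(C)(C)C)c1O`, has not yet been measured. It differs from compound 2 in one place: 4-carboxy-3-chlorophenyl in place of 4-carboxy-2-methylphenyl on an oxygen on a saturated carbon. Within the data shown here, no pair of measured compounds shows a step of this kind, so the expectation rests only on the two values in hand and on the small nature of the change, a swap of substituents on the acid-bearing ring. The step from compound 2 to compound 3 is expected to be a 1.0-fold lower number from compound 2 to compound 3 (0.01 log units; within the scatter), with no clear direction beyond the scatter. For compound 3 the expected value in this assay is 1500 nM, within a range from 600 nM to 3800 nM.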

Compound 3, half-maximal effective concentration: 860 nM
For compound 3 the middle estimate is 1.7-fold (0.24 log units) above the measured one; the range from low to high includes it.
By their numbers in this assay, from the lowest: compounds 3, 1 and 2 (each within the scatter of the next).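

Within the data shown here, this is the first single-place comparison, since compounds 1 and 2 differ in more than one place. In this assay, 4-carboxy-3-chlorophenyl in place of 4-carboxy-2-methylphenyl on an oxygen on a saturated carbon gives a 1.8-fold lower number from compound 2 to compound 3 (0.25 log units; within the scatter) and so this exchange of one substituted acid-bearing ring for another leaves the number level with that of compound 2, at least for this single pair. Nothing measured here explains why the two rings read alike.

On these data alone, whether this position stays as undemanding for other groups remains open, for example a ring carrying trifluoromethyl or methoxy instead of chlorine or methyl. Also open, as far as these compounds go, is whether replacing the carboxylic acid itself with a tetrazole or an amide would hold the number or move it beyond the scatter.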